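The compounds below may be only part of what the source reports. "The series", "measured", "known", "first", "only" and "open" are said of these compounds alone.

Compound 1 `O=C(O)CCC/C=C\C[C@@H]1[C@@H](/C=C/[C@@H](O)CCc2ccccc2)[C@H](O)C[C@@H]1O`, compound 2 `O=C(O)CCC[C@@H]1CC[C@@H]2[C@@H](/C=C/[C@@H](O)COc3ccccc3)[C@H](O)C[C@@H]2O1` and compound 3 `O=C(O)CCC1=CC[C@@H]2[C@@H](/C=C/[C@@H](O)COc3ccccc3)[C@H](O)C[C@@H]2OC1` were all examined in an ADME assay on CHO cells for agonist activity at prostacyclin receptor (Homo sapiens), read by HTRF and cAMP accumulation; on this read-out lower numbers stand for an effect already at smaller amounts and higher numbers for an effect only at larger amounts of compound. Compound 2 gives 26 nM. Compound 1 reaches only the limit of the assay, > 10000 nM. Compound 3 likewise reaches only a limit, > 10000 nM, and so is not placed at a measured number. Two of the three compounds thus sit at the limit of > 10000 nM in this assay, at which 2 of the 3 values shown sit, with compound 2 alone giving a number. Compound 4 `O=C(O)CCCCC1=CC[C@@H]2[C@@H](/C=C/[C@@H](O)COc3ccccc3)[C@H](O)C[C@@H]2OC1` differs from compound 3 by 2-carboxyethyl in place of carboxy on a saturated chain carbon, two bonds along the chain from a double-bonded ring carbon. For the measured compounds named here, no step between measured compounds matches this change. The longer acid chain of compound 4 is expected to move the read-out toward smaller amounts, an expected step of an at least 33-fold lower number from compound 3 to compound 4 (1.52 log units; beyond the scatter). Compound 4 is therefore estimated at 300 nM, between 30 nM and 5000 nM, with a real chance that only a limit is returned.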

Compound 4, half-maximal effective concentration: > 10000 nM
Compound 4 gave a limit, no number; the forecaster's own chance of this, stated with the estimate: 25%; middle value at least 33-fold (1.52 log units) from the limit.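

Compound 3 and compound 4 both return only a limit, so no step can be read between them: the limit of > 10000 nM in this assay, at which 3 of the 4 values shown sit. The compounds shown leave open whether any other acid chain on this core gives a measured number in this assay at all.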